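This account rests on a few compounds, and the source may have more. Where it says the series, first, only, none or still open, it means among the compounds named here.

Compound 1, `Cc1cc(O)c(C2=NN(c3ccc(S(N)(=O)=O)cc3)C(c3ccccc3Cl)C2)cc1Cl`, in a functional assay on HOP-62 cells (Homo sapiens) for antiproliferative activity, with a stated time of 48 h (on this read-out higher numbers stand for lower toxicity in this test and lower numbers for higher toxicity in this test), gives 8530 nM.
Compound 2, `Cc1cc(O)c(C2=NN(c3ccc(S(N)(=O)=O)cc3)C(/C=C/c3ccccc3)C2)cc1Cl`, gives 37500 nM.
Compound 3, `COc1ccc(C2CC(c3cc(Cl)c(C)cc3O)=NN2c2ccc(S(N)(=O)=O)cc2)cc1OC`, gives 52400 nM.

Compound 3 holds the highest of these three numbers; one of its steps reads a 1.4-fold higher number from compound 2 to compound 3 (0.15 log units; within the scatter), while the other reads a 6.1-fold higher number from compound 1 to compound 3 (0.79 log units; beyond the scatter). Compound 4, `COc1ccc(C2CC(c3cc(Cl)c(C)cc3O)=NN2c2ccc(S(N)(=O)=O)cc2)c(OC)c1OC`, differs from compound 3 by methoxy in place of hydrogen on an aromatic carbon. For the measured compounds named here, no measured step adds a group to the ring that sits on the saturated ring carbon; the steps that touch that part swap the whole ring, a 4.4-fold higher number from compound 1 to compound 2 (0.64 log units; beyond the scatter) and a 6.1-fold higher number from compound 1 to compound 3 (0.79 log units; beyond the scatter), both modest. Nothing here points to a direction for adding one methoxy, so the step is expected to stay within the scatter, a 1.0-fold lower number from compound 3 to compound 4 (0.02 log units; within the scatter). Compound 4 is therefore estimated at 50000 nM, between 20000 nM and 130000 nM.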

Compound 4, concentration lethal to 50% of the cells: 9920 nM
Beside the measured number, compound 4's estimate is 5.0-fold (0.70 log units) above it; measured number outside the range, below it.
By their numbers in this assay, from the lowest: compounds 1 and 4 (each within the scatter of the next); then compounds 2 and 3 (each within the scatter of the next).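

In this assay, the ring on the saturated ring carbon responds to a single added methoxy, not only to a swap of the whole ring (a 5.3-fold lower number from compound 3 to compound 4 (0.72 log units; beyond the scatter)). With this one group, ortho to a large group, the 2,3,4-trimethoxyphenyl compound parts from the 2-phenylethenyl compound (a 3.8-fold lower number from compound 2 to compound 4 (0.58 log units; beyond the scatter)) and sits level with the 2-chlorophenyl compound (a 1.2-fold higher number from compound 1 to compound 4 (0.07 log units; within the scatter)). No measurement here accounts for the shift. From the compounds shown here alone, whether the drop belongs to methoxy itself or to this place on the ring stays open, and a hydroxyl, an amine or a fluorine there could tell these apart.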